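Swapping the ring on the amide-type nitrogen of compound 1

The compounds below may be only part of what the source reports. "The series", "measured", "known", "first", "only" and "open" are said of these compounds alone.

Measured so far are compound 1 `O=C1O[C@]2(CC[C@H](CNc3cnn(-c4ccccc4F)c3)CC2)CN1c1cncnc1`, compound 2 `O=C1O[C@]2(CC[C@H](CNc3ccc(-c4ncccc4F)cn3)CC2)CN1c1cccnn1` and compound 3 `O=C1O[C@]2(CC[C@H](CNc3nc(-c4ccccn4)cs3)CC2)CN1c1ccccn1`. In a functional assay for antagonist activity at Neuropeptide Y receptor type 5 (Homo sapiens) (a higher number here means a weaker inhibitor, a lower number a stronger inhibitor), compound 1 gives 0.0398 nM, the lowest number of the three. Compound 3 gives 0.0794 nM, which lies within the scatter of compound 1, while compound 2 gives 0.316 nM, a gap beyond the scatter. Compound 4 `O=C1O[C@]2(CC[C@H](CNc3cnn(-c4ccccc4F)c3)CC2)CN1c1cccnn1` has not been measured. It differs from compound 1 in one place: pyridazin-3-yl in place of pyrimidin-5-yl on an amide-type nitrogen in a ring. Among the measured compounds shown here, no pair of measured compounds differs by this single change alone, so the size of the step is open. Compound 2 also carries pyridazin-3-yl at the amide-type nitrogen, but it differs from compound 1 elsewhere as well, so its higher number is only a loose hint towards a weaker inhibitor. The step from compound 1 to compound 4 in this assay is expected to be a modest rise, close to the scatter, a 2.0-fold higher number from compound 1 to compound 4 (0.30 log units; within the scatter). Compound 4 is estimated at 0.08 nM in this assay, with a range from 0.03 nM to 0.25 nM.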

Compound 4, inhibition constant: 0.1 nM
Estimate against measurement, compound 4: 1.3-fold (0.10 log units) below; the range from low to high includes it.
By their numbers in this assay, from the lowest: compounds 1, 3 and 4 (each within the scatter of the next, the first and the last beyond it); then compound 2.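

Among the compounds shown here, the change of pyrimidin-5-yl to pyridazin-3-yl on the amide-type nitrogen gives the first reading of this position with the rest of the core held fixed: in this assay there is a 2.5-fold higher number from compound 1 to compound 4 (0.40 log units; beyond the scatter), so the position responds to the arrangement of the ring atoms alone. The two rings match in heavy atoms, donors and acceptors, so these counts do not separate them. Nothing at hand gives a reason for the step.

Going by these compounds, whether the same step holds with the other groups on the far side of the core, as carried by compound 2 and compound 3, remains open. Also open, on these data alone, is how a pyrazin-2-yl ring, or a plain methyl group, on the same nitrogen would read in this assay against pyrimidin-5-yl and pyridazin-3-yl.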